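Swapping Ethyl for Methylsulfonyl on the Shared Core

The source may report more compounds than this note shows. Statements on the series, on what has been measured and on what is new or still open speak of the compounds shown alone.

Three compounds have so far been measured in an in vitro assay on BTI-TN-5B1-4 cells for inhibition of Amine oxidase [flavin-containing] B (Homo sapiens), read by fluorescence; a lower number here means a stronger inhibitor, a higher number a weaker inhibitor:
compound 1 `CC(C)CNC(=O)c1cc2ccccc2oc1=O`: 3270 nM
compound 2 `O=C(Nc1cccc(C(F)(F)F)c1)c1cc2ccccc2oc1=O`: 250 nM
compound 3 `CCc1ccc(NC(=O)c2cc3ccccc3oc2=O)cc1`: 890 nM

Compound 3 gives the second highest of these three numbers. Compound 2 gives a lower number and compound 1 a higher one, and both gaps lie beyond the usual scatter, so compound 3 sits clearly between them as a middling inhibitor. The next compound, compound 4 `CS(=O)(=O)c1ccc(NC(=O)c2cc3ccccc3oc2=O)cc1`, differs from compound 3 in one place: methylsulfonyl in place of ethyl on an aromatic carbon. Within the data shown here, no measured pair shows this same change, so its effect has not been seen directly. The expectation is a step towards a higher number, larger than the scatter, a 3.4-fold higher number from compound 3 to compound 4 (0.53 log units; beyond the scatter). Compound 4 is thus expected to give 3000 nM, with a likely range from 800 nM to 12000 nM.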

Compound 4, half-maximal inhibitory concentration: 1.4 nM
For compound 4 the middle estimate is 2100-fold (3.33 log units) above the measured one; the measured number lies below the stated range.
By their numbers in this assay, from the lowest: compound 4; then compound 2; then compound 3; then compound 1.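

On this aromatic carbon, para to a large group, methylsulfonyl in place of ethyl gives a 640-fold lower number from compound 3 to compound 4 (2.80 log units; beyond the scatter). The earlier compounds shown here did not show that a single change at this position, where a group with hydrogen-bond acceptors replaces one without them, can produce a step this large. Nothing measured here explains why the step is so large.

Going by these compounds, it remains open whether other groups on this carbon, such as an amine, a nitrile or a sulfonamide, would give a similar step. It is also unknown whether methylsulfonyl would give such a step on a different aromatic carbon.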